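Phenyl ether in place of benzyl ether on the hydroxamate

The compounds below may be only part of what the source reports. "The series", "measured", "known", "first", "only" and "open" are said of these compounds alone.

Compound 1 `CC(=O)N(O)C(C)c1ccc(OCc2ccccc2)cc1` is the reference point of the series. Within the data shown here, in an assay on RBL-1 cells for inhibition of Polyunsaturated fatty acid 5-lipoxygenase (Rattus norvegicus) (a lower number here means a stronger inhibitor, a higher number a weaker inhibitor), compound 1 gives 280 nM, the lowest of the three numbers so far. Compound 2 `CC(c1ccc(OCc2ccccc2)cc1)N(O)C=O` gives 940 nM and compound 3 `CC(c1ccc(OCc2ccccc2)cc1)N(O)C(=O)c1ccccc1` gives 690 nM. All three measured steps sit on the carbonyl carbon: a 3.4-fold higher number from compound 1 to compound 2 (0.53 log units; beyond the scatter), a 2.5-fold higher number from compound 1 to compound 3 (0.39 log units; beyond the scatter), and a 1.4-fold lower number from compound 2 to compound 3 (0.13 log units; within the scatter). Compound 4 `CC(=O)N(O)C(C)c1ccc(Oc2ccccc2)cc1` differs from compound 1 at a different place: phenyl in place of benzyl on an oxygen on an aromatic ring. Among the measured compounds shown here, none of the measured steps touches the aryl ether, so none gives a direct reading on this change; they show only that compound 1 stands lowest and that each change made to it so far has moved the number up by a modest amount. With no comparison to anchor it, the estimate for compound 4 stays near compound 1 with a lean toward a higher number, and the expected step is a 1.8-fold higher number from compound 1 to compound 4 (0.25 log units; within the scatter). Compound 4 is estimated at 500 nM, with a range from 150 nM to 1800 nM.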

Compound 4, half-maximal inhibitory concentration: 370 nM
Estimate against measurement, compound 4: 1.4-fold (0.13 log units) above, and the stated range covers the measured number.
By their numbers in this assay, from the lowest: compounds 1, 4, 3 and 2 (each within the scatter of the next, the first and the last beyond it).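

Phenyl in place of benzyl on an oxygen on an aromatic ring gives the first reading away from the carbonyl carbon, and in this assay it is a step of a 1.3-fold higher number from compound 1 to compound 4 (0.12 log units; within the scatter). Compound 1 and compound 4 therefore cannot be told apart at this position, whereas the steps from compound 1 on the carbonyl carbon lie beyond the scatter. Nothing available bears on why benzyl and phenyl read alike here.

On these data alone, it remains open whether phenyl in place of benzyl reads the same with hydrogen or phenyl on the carbonyl carbon, as in compound 2 and compound 3. The compounds shown also leave open how a longer chain such as phenethyl, or a small group such as methyl, would read on this oxygen.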